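Triazole methyl removed: stability notes on a pyridone series

This account rests on a few compounds, and the source may have more. Where it says the series, first, only, none or still open, it means among the compounds named here.

Measured so far in an ADME assay on microsomes from liver (Homo sapiens) for metabolic stability; on this read-out lower numbers stand for a shorter-lived compound and higher numbers for a longer-lived compound:
compound 1 `CCn1ncc2c(F)cc(-c3ccc(C(CC)(CC)c4nnc(C)[nH]4)c(=O)[nH]3)cc21`: > 3 h
compound 2 `CC(C)C(c1ncco1)c1ccc(-c2ccc3cccc(F)c3c2)[nH]c1=O`: 0.178 h

Compound 1 gives > 3 h in this assay, which is a limit of the assay and not a number. Compound 1 thus sits at the limit of > 3 h in this assay, at which 1 of the 2 values shown sits. Compound 2 gives 0.178 h in this assay, a short half-life. Among the compounds with values here, compound 1 and compound 2 differ in more than one place, so no single step is drawn between them; their two values only mark where each stands.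

Compound 3 `CCn1ncc2c(F)cc(-c3ccc(C(CC)(CC)c4nnc[nH]4)c(=O)[nH]3)cc21` differs from compound 1 by hydrogen in place of methyl on an aromatic carbon; cut one bond further out, the change reads 5-methyl-4H-1,2,4-triazol-3-yl to 4H-1,2,4-triazol-3-yl. Within the data shown here, no measured step of this kind is available. The expected step from compound 1 to compound 3 is a number no higher from compound 1 to compound 3 (the limit leaves the size open), none beyond the scatter. Compound 3 is estimated at 3 h, in the range 1.2 h to 6 h, and may again be reported only as a limit.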

Compound 3, half-life in the Homo sapiens assay: 2.7 h
Compound 3: middle estimate off by 1.1-fold (0.05 log units), on the high side, within the range that was stated.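

Within the data shown here, this is the first step that changes one place only. In the Homo sapiens assay, hydrogen in place of methyl on an aromatic carbon gives an at least 1.1-fold lower number from compound 1 to compound 3 (0.04 log units; that floor lies within the scatter), and compound 3 remains a longer-lived compound at 2.7 h. Compound 1 stands at a limit of the assay and not at a number: the limit of > 3 h in the Homo sapiens assay, at which 1 of the 3 values shown sits.

In a physicochemical assay for solubility, measured as kinetic solubility, at pH 2 (a higher number here means a more soluble compound, a lower number a less soluble compound), compound 1 gives 33900 nM and compound 3 gives 39100 nM, which is a 1.2-fold higher number from compound 1 to compound 3 (0.06 log units; within the scatter).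

On these data alone, the full size of the step in half-life stays open, as only a floor can be read from it. Also open, as far as these compounds go, is how an ethyl group or an amine on this aromatic carbon would read in either assay.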